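Replacing the aryl ether at the bicyclic core with isobutyl

The compounds below may be only part of what the source reports. "The series", "measured", "known", "first", "only" and "open" are said of these compounds alone.

Three members of the series have been measured in an ADME assay on HepG2 cells (Homo sapiens) for cytotoxicity, read by luminescence, CellTiter-Glo and ATP content, with a stated time of 72 h; on this read-out higher numbers stand for an effect only at larger amounts of compound and lower numbers for an effect already at smaller amounts. Compound 1 `COc1cccc(CNCCCNc2ccnc3cc(Cc4ccccc4)ccc23)c1O` gives 5720 nM. Compound 2 `COc1cccc(Oc2ccc3c(NCCCNCc4cccc(OC)c4O)ccnc3c2)c1` gives 5300 nM. Compound 3 `COc1cccc(CNCCCNc2ccnc3cc(Oc4ccccc4)ccc23)c1O` gives 6800 nM. Compound 3 sits together with the other two: in this assay the step of a 1.2-fold higher number from compound 1 to compound 3 (0.08 log units; within the scatter) and the step of a 1.3-fold higher number from compound 2 to compound 3 (0.11 log units; within the scatter) are both within the scatter, and a 1.1-fold lower number from compound 1 to compound 2 (0.03 log units; within the scatter) likewise.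

Compound 4 `COc1cccc(CNCCCNc2ccnc3cc(CC(C)C)ccc23)c1O` differs from compound 3 by isobutyl in place of phenoxy on an aromatic carbon. The measured step that bears on this change is the exchange at the same aromatic carbon in a 1.2-fold higher number from compound 1 to compound 3 (0.08 log units; within the scatter), where phenoxy replaced benzyl without moving the number beyond the scatter; the related exchange in a 1.1-fold lower number from compound 1 to compound 2 (0.03 log units; within the scatter) was also flat. Among the measured compounds shown here, no measured pair shows an open-chain group at this position, so the expectation rests on how little the three aromatic substituents changed the cytotoxicity number.

Compound 4 is therefore expected to stay in the same range, with a step of a 1.1-fold lower number from compound 3 to compound 4 (0.05 log units; within the scatter) that is expected to lie within the scatter. The estimated value for compound 4 in this assay is 6000 nM, with a range from 3000 nM to 12000 nM.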

Compound 4, half-maximal effective concentration: 2920 nM
For compound 4 the middle estimate is 2.1-fold (0.31 log units) above the measured one, and the stated range ends above it.
By their numbers in this assay, from the lowest: compounds 4, 2, 1 and 3 (each within the scatter of the next, the first and the last beyond it).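

In this assay, among the compounds shown here, the isobutyl group gives the first step at this aromatic carbon that lies beyond the scatter, with a 2.3-fold lower number from compound 3 to compound 4 (0.37 log units; beyond the scatter) as phenoxy, with its aromatic ring, leaves and the open chain enters, whereas the earlier exchanges among benzyl, phenoxy and 3-methoxyphenoxy all stayed within it. The separation is limited to this one pair: a 1.8-fold lower number from compound 2 to compound 4 (0.26 log units; within the scatter) and a 2.0-fold lower number from compound 1 to compound 4 (0.29 log units; within the scatter) are both within the scatter, so compound 1 and compound 2 go against any reading that isobutyl sets itself apart from all the ring-bearing groups at this position. The data shown offer no explanation for the step from phenoxy to isobutyl.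

Open at this aromatic carbon is whether a cyclohexyl group, which keeps a ring but is not aromatic, would fall with isobutyl or with phenoxy, and whether a longer chain such as n-hexyl would extend the step or leave the number unchanged. Also open, going by these compounds, is how an amine or a carboxylic acid at the same carbon would read in this assay against the carbon-only isobutyl chain.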